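Three Measured Compounds and a Fourth Awaiting Measurement

A few compounds are considered here, and "the series" means these few. Any claim that something is new, unique, unknown or untested is made for them only; others in the source may bear on it.

Of the compounds shown here, three sharing a common core have been measured in a physicochemical assay for lipophilicity, measured as octanol-water partition; on this read-out lower numbers stand for lower lipophilicity and higher numbers for higher lipophilicity. Compound 1 `COc1ccc(/C=N/NC(=O)COc2cccc3ccccc23)cc1OC` gives 3.51, compound 3 `O=C(COc1cccc2ccccc12)N/N=C/c1c[nH]c2ccccc12` gives 3.79, and compound 2 `C/C(=N\NC(=O)COc1cccc2ccccc12)c1ccc(O)cc1` gives 4.44, the highest of the three, with its gaps to compound 3 and to compound 1 both lying beyond the scatter. Compound 4 `C/C(=N\NC(=O)COc1cccc2ccccc12)c1cccc([N+](=O)[O-])c1` has not yet been measured. It differs from compound 2 in one place: 3-nitrophenyl in place of 4-hydroxyphenyl on a carbon with a double bond to nitrogen. Going by the values given here, no measured pair of compounds that differs in a single place is available, so the size of this change can only be anticipated. The expected step in this assay is a number 0.16 log units higher from compound 2 to compound 4 (within the scatter), a small rise that may not clearly exceed the scatter. Compound 4 is accordingly estimated at 4.6, within a range from 4.1 to 5.1.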

Compound 4, partition coefficient: 3.37
For compound 4 the middle estimate is 1.23 log units above the measured one; measured number below the stated range.
By their numbers in this assay, from the lowest: compounds 4, 1 and 3 (each within the scatter of the next, the first and the last beyond it); then compound 2.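

In this assay, going by these compounds alone, 3-nitrophenyl in place of 4-hydroxyphenyl on a carbon with a double bond to nitrogen gives a number 1.07 log units lower from compound 2 to compound 4 (beyond the scatter) and provides the first step in this set that changes only one place. It shows that the read-out at this position can shift well beyond the scatter with the group carried there. Nothing given here accounts for the size of this step.

The compounds shown leave open whether the step follows the loss of the hydroxyl or the arrival of the nitro group. They also leave open how a phenyl ring carrying an amine or a carboxylic acid would read at this position.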